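The source may hold more compounds than are shown below. What is called first, only, known or untested is meant among the compounds shown, and "the series" means these compounds.

Compound 1 `COc1ccc(C2=NN(C3=NC(=O)/C(=C4\C(=O)Nc5ccc(Br)cc54)S3)C(c3ccc(OC)cc3)C2)cc1` and compound 2 `COc1ccc(C2=NN(C3=NC(=O)/C(=C4\C(=O)Nc5ccc(Cl)cc54)S3)C(c3ccc(OC)cc3)C2)cc1` share one core; in a functional assay on cells (Cancer cell lines, Homo sapiens) for cytotoxicity, read by sulforhodamine B assay, with a stated time of 48 h (a lower number here means a stronger inhibitor of growth, a higher number a weaker inhibitor of growth), compound 1 gives 270 nM and compound 2 gives 250 nM. For the measured compounds named here, the single change between them, (chloro in place of bromo on an aromatic carbon), moves the number by a 1.1-fold lower number from compound 1 to compound 2 (0.03 log units; within the scatter), so the two halogens are not separated by the measurement. Compound 3 `COc1ccc(-c2cc(-c3ccc(Cl)cc3)n(C3C(=O)Nc4ccc(Br)cc43)n2)cc1` carries a different core; the difference between the two cores is not broken down here. In this assay compound 3 gives 7650 nM, the highest of the three numbers and well beyond the scatter from compound 1 and compound 2. Compound 4 `COc1ccc(-c2cc(-c3ccc(Cl)cc3)n(C3C(=O)Nc4ccc(Cl)cc43)n2)cc1` has not yet been measured. It stands to compound 3 as compound 2 stands to compound 1: chloro in place of bromo on an aromatic carbon, the same change at the same place. Going by the values given here, on that basis a small step is expected from compound 3 to compound 4, a 1.1-fold lower number from compound 3 to compound 4 (0.04 log units; within the scatter), because a 1.1-fold lower number from compound 1 to compound 2 (0.03 log units; within the scatter) is the only precedent for this change in this set and lies within the scatter. Compound 4 is therefore estimated at 7000 nM, most likely between 3000 nM and 16000 nM, in this assay.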

Compound 4, concentration for 50% growth inhibition: 6490 nM
Estimate against measurement, compound 4: 1.1-fold (0.03 log units) above; the measured number falls inside the stated range.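

In this assay chloro in place of bromo on an aromatic carbon gives a 1.2-fold lower number from compound 3 to compound 4 (0.07 log units; within the scatter), so on the core of compound 3, as on the core of compound 1, the measurement does not separate the two halogens. Set side by side, the two steps agree across the two cores: the same change on two cores in this assay, a 1.1-fold lower number (0.03 log units; within the scatter) from compound 1 to compound 2 and a 1.2-fold lower number (0.07 log units; within the scatter) from compound 3 to compound 4, 1.1-fold (0.04 log units) apart, within the scatter of two such steps. This shows that the exchange of these two halogens, at this one place, carries from one core to the other without a step beyond the scatter; it does not show that any other change at this place would carry over in the same way, and it says nothing about what the two cores themselves contribute to the numbers.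

Still open, as far as these compounds go, is whether an amine, a nitrile or a carboxylic acid in place of the halogen would move the number on either core. Also open, from the compounds shown here alone, is whether a longer chain in place of the methoxy groups would do so.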